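The source may hold more compounds than are shown below. What is called first, only, known or untested is meant among the compounds shown, and "the series" means these compounds.

So far, two compounds built on the same core have been measured in an ADME assay on microsomes from liver (Homo sapiens) for pharmacokinetics; a higher number here means faster removal of the compound, a lower number slower removal. Compound 1 `Cc1c(Nc2nc(N)c3c(C#N)c(N4CCC[C@H]4C)n(C)c3n2)cnn1C` gives 41.7 mL/min/kg and compound 2 `Cc1c(Nc2nc(N)c3c(C#N)c(N4CCC[C@H]4C)n(C)c3n2)cnn1CC(C)(C)O` gives 30 mL/min/kg. These two numbers lie within the usual scatter of each other, so compound 2 cannot yet be told apart from compound 1. The next compound, compound 3 `Cc1c(Nc2nc(N)c3c(C#N)c(N4CCC[C@H]4C)n(C)c3n2)cnn1[C@@H]1CCOC1`, keeps the core and changes one group: oxolan-3-yl in place of 2-hydroxy-2-methylpropyl on an aromatic nitrogen. For the measured compounds named here, the new group brings a ring to this place, and no measured compound carries one there, so the data offer no direct precedent. Going by the values given here, the only measured step that alters the group on this nitrogen, a 1.4-fold lower number from compound 1 to compound 2 (0.14 log units; within the scatter), is small, so no change beyond the scatter is expected in this assay, in either direction. The estimated step is a 1.2-fold higher number from compound 2 to compound 3 (0.07 log units; within the scatter). For compound 3 the expected clearance is 35 mL/min/kg, with an estimated range from 20 mL/min/kg to 60 mL/min/kg.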

Compound 3, clearance: 28.3 mL/min/kg
For compound 3 the middle estimate is 1.2-fold (0.09 log units) above the measured one; the range from low to high includes it.
By their numbers in this assay, from the lowest: compounds 3, 2 and 1 (each within the scatter of the next).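

In this assay, the step that replaces the open 2-hydroxy-2-methylpropyl chain with the oxolan-3-yl ring is a 1.1-fold lower number from compound 2 to compound 3 (0.03 log units; within the scatter) and so cannot be told from repeat-measurement noise, even though the same count of heavy atoms is now tied up in a ring with a defined stereocentre and the hydrogen-bond donor is gone. Set against the small methyl group, the ring gives a 1.5-fold lower number from compound 1 to compound 3 (0.17 log units; within the scatter), so the methyl group, the chain and the ring, all on this aromatic nitrogen, stand within the scatter of one another, and the earlier pair alone could not show that a ring fits this pattern too. No outside measurement bears on this result.

What the three compounds leave open is whether any group on this nitrogen can shift the clearance beyond the scatter, for instance an amine such as piperidin-4-yl, a carboxylic acid or a longer chain. Also open, going by these compounds, is whether the mirror-image form of the oxolan-3-yl ring would give a number that differs from that of compound 3.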